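The compounds below may be only part of what the source reports. "The series", "measured", "known", "first", "only" and "open" are said of these compounds alone.

Within the data shown here, compound 2, `N#C/C(=C\N1CCN(C(=O)c2ccco2)C1=S)C(N)=O`, gives 4000 nM in a functional assay on MT4 cells (Homo sapiens) for antiproliferative activity, read by MTT assay (a lower number here means a stronger inhibitor, a higher number a weaker inhibitor), the lowest of the two numbers known so far. Its nearest neighbour is compound 1, `N#C/C(=C\N1CCN(C(=O)c2ccco2)C1=S)C(=O)Nc1ccc(Cl)cc1`, which gives 6500 nM in this assay; the change a 1.6-fold lower number from compound 1 to compound 2 (0.21 log units; within the scatter) lies within the scatter, so the two compounds cannot be ranked against each other.

Compound 3, `N#C/C(=C\N1CCN(C(=O)c2ccco2)C1=S)C(=O)c1ccccc1`, differs from compound 2 in one place: phenyl in place of amino on a carbonyl carbon. Among the measured compounds shown here, the one measured step, from compound 1 to compound 2, removed an aromatic ring at the amide end of the chain, while the change to compound 3 adds an aromatic ring at the carbonyl carbon and takes away a hydrogen-bond donor. For the measured compounds named here, no measured step concerns that carbonyl carbon, so the step of a 1.6-fold lower number from compound 1 to compound 2 (0.21 log units; within the scatter) bears on it only loosely, and that step stayed within the scatter.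

On that footing, compound 3 is expected to show a change of no change at the digits printed from compound 2 to compound 3 (within the scatter) in this assay, that is, nothing beyond the scatter in either direction. Compound 3 is therefore estimated at 4000 nM, with a likely range from 1500 nM to 12000 nM.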

Compound 3, half-maximal inhibitory concentration: 3000 nM
Compound 3: middle estimate off by 1.3-fold (0.12 log units), on the high side; the measured number falls inside the stated range.
By their numbers in this assay, from the lowest: compounds 3, 2 and 1 (each within the scatter of the next, the first and the last beyond it).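

In this assay, putting phenyl in place of amino on the carbonyl carbon gives a 1.3-fold lower number from compound 2 to compound 3 (0.12 log units; within the scatter) and so does not separate the two compounds, even though this change from carbamoyl to benzoyl removes the hydrogen-bond donor of the amino group and brings in a six-membered aromatic ring. Among these compounds, replacing (4-chlorophenyl)amino with phenyl at the same carbon gives a 2.2-fold lower number from compound 1 to compound 3 (0.34 log units; beyond the scatter) and is the only step among the three compounds to pass the scatter, although modestly. Nothing measured here explains either step.

The compounds shown leave open whether the loss of the amide nitrogen or the loss of the chlorine lies behind the step from the (4-chlorophenyl)amino group to phenyl, as that step changes both at once and a phenylamino group on the carbonyl carbon would part the two. They also leave open how this carbon responds to groups other than amino and aromatic ones, such as a methyl group or the hydroxyl of a carboxylic acid.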